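The compounds below may be only part of what the source reports. "The series", "measured", "known", "first", "only" and "open" are said of these compounds alone.

In a functional assay on RKO cells (Homo sapiens) for cytotoxicity, read by resazurin assay, with a stated time of 72 h (a lower number here means a stronger inhibitor, a higher number a weaker inhibitor), three compounds sharing one core have been measured. Compound 1 `COc1ccc(Nc2nc(-n3cnc4ccccc43)cs2)cc1` reaches only the edge of the assay: in this assay compound 1 gives > 100000 nM, which is a limit and not a number. Compound 2 `Cc1nc2ccccc2n1-c1csc(Nc2ccc(Br)cc2)n1` gives 60000 nM. Compound 3 `Cc1nc2ccccc2n1-c1csc(Nc2ccccc2)n1` gives 50000 nM; of the two numbers it lies nearest compound 2, and the step of a 1.2-fold lower number from compound 2 to compound 3 (0.08 log units; within the scatter) falls within the scatter, so the two cannot be set in order. Compound 4 `COc1ccc(Nc2nc(-n3c(C)nc4ccccc43)cs2)cc1` has not yet been measured and differs from compound 3 by methoxy in place of hydrogen on an aromatic carbon. Within the data shown here, the one measured step at that same place, a 1.2-fold lower number from compound 2 to compound 3 (0.08 log units; within the scatter), changed the number hardly at all, so a change of the substituent there has so far made no difference beyond the scatter. Compound 1, which carries the same methoxy group, gave no number at all. Compound 4 is therefore expected to remain weak, with a step of a 1.4-fold higher number from compound 3 to compound 4 (0.15 log units; within the scatter) of no clear size. The estimate for compound 4 is 70000 nM, in the range 30000 nM to 200000 nM.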

Compound 4, half-maximal inhibitory concentration: 52500 nM
For compound 4 the middle estimate is 1.3-fold (0.12 log units) above the measured one, and the stated range covers the measured number.
By their numbers in this assay, from the lowest: compounds 3, 4 and 2 (each within the scatter of the next). At a limit, above all of these: compound 1.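

In this assay, methoxy on the six-membered aromatic ring, para to a large group, is a third substituent at a place where only hydrogen and bromo could be compared before, and it stands apart from neither: a 1.1-fold higher number from compound 3 to compound 4 (0.02 log units; within the scatter) and a 1.1-fold lower number from compound 2 to compound 4 (0.06 log units; within the scatter). Compounds 2, 3 and 4 therefore cannot be set in order, so among these three groups the choice at this position makes no difference beyond the scatter. On these data alone, the methyl on the shared core reads an at least 1.9-fold lower number from compound 1 to compound 4 (0.27 log units; that floor lies within the scatter), but that is only a floor set by a limit and not a number, so its true size stays unknown: the limit of > 100000 nM in this assay, at which 1 of the 4 values shown sits.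

As far as these compounds go, whether an amine, a carboxylic acid or a longer chain at this position would move the number beyond the scatter remains open. So does the size of the methyl step.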